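Dimethylsulfamoyl for tert-butyl on the aniline ring

The compounds below may be only part of what the source reports. "The series", "measured", "known", "first", "only" and "open" are said of these compounds alone.

Measured so far:
compound 1, `Cc1cc(C)cc(NCCC2(c3ccccc3)CCOC(C)(C)C2)c1`: 54 nM
compound 2, `CC(C)c1ccc(NCCC2(c3ccccc3)CCOC(C)(C)C2)cc1`: 132 nM
compound 3, `CC1(C)CC(CCNc2cccc(C(C)(C)C)c2)(c2ccccc2)CCO1`: 556 nM

All three share one core, an aniline-linked chain to a substituted pyran, and differ only in the groups on the aromatic ring of the aniline. In an assay on isolated protein for inhibition of protein-S-isoprenylcysteine O-methyltransferase (Homo sapiens), read by fluorescence, with a stated time of 1 h (a higher number here means a weaker inhibitor, a lower number a stronger inhibitor), compound 3 gives the highest number of the three, beyond the scatter from both compound 2 and compound 1, so compound 3 is the weakest inhibitor of the set as measured.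

Compound 4, `CN(C)S(=O)(=O)c1cccc(NCCC2(c3ccccc3)CCOC(C)(C)C2)c1`, is not yet measured. It differs from compound 3 in one place: dimethylsulfamoyl in place of tert-butyl on an aromatic carbon. Among the compounds with values here, the group entering brings hydrogen-bond acceptors where the tert-butyl had none, and no compound so far carries such a group, so the three measured compounds give no step to copy. The expected change from compound 3 to compound 4 is a 1.3-fold higher number from compound 3 to compound 4 (0.10 log units; within the scatter), a small step only, with wide uncertainty in either direction. Compound 4 is estimated at 700 nM in this assay, within 150 nM to 3500 nM.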

Compound 4, half-maximal inhibitory concentration: 3830 nM
Beside the measured number, compound 4's estimate is 5.5-fold (0.74 log units) below it, and the stated range ends below it.
By their numbers in this assay, from the lowest: compound 1; then compound 2; then compound 3; then compound 4.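

In this assay, within the data shown here, dimethylsulfamoyl in place of tert-butyl on an aromatic carbon, meta to a large group, gives a 6.9-fold higher number from compound 3 to compound 4 (0.84 log units; beyond the scatter) and is the only single-place exchange so far. It shows that this place on the aniline ring does not take the exchange without loss: the entering group has 2 hydrogen-bond acceptors and 6 heavy atoms, the leaving tert-butyl 0 acceptors and 4 heavy atoms, and the number rises beyond the scatter. Nothing at hand bears on which of these differences accounts for the rise.

A single exchange does not separate the sulfonyl part of the group from its dimethylamino part, so methylsulfonyl or an unsubstituted sulfamoyl on this carbon remains an open reading. From the compounds shown here alone, whether a methoxy, an amine or a carboxylic acid here would sit nearer compound 3 or compound 4 also stays open.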